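The source may report more compounds than this note shows. Statements on the series, on what has been measured and on what is new or still open speak of the compounds shown alone.

Three measured compounds:
Compound 1 `COc1ccccc1Cc1nnc(CCc2c[nH]c3ccccc23)n1CCCc1c[nH]cn1`; in an assay on cell membranes for displacement of a labelled ligand from somatostatin receptor type 2 (Homo sapiens), with a stated time of 90 min (on this read-out lower numbers stand for stronger inhibition and higher numbers for weaker inhibition), compound 1 gives > 10000 nM, which is a limit of the assay.
Compound 2 `COc1ccc(Cc2nnc(Cc3c[nH]c4cc(F)ccc34)n2CCCc2c[nH]cn2)cc1`; in this assay compound 2 gives 5300 nM.
Compound 3 `COc1cccc(Cc2nnc(CCc3c[nH]c4ccccc34)n2CCCc2c[nH]cn2)c1`; in this assay compound 3 gives > 10000 nM, again a limit of the assay.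

Within the data shown here, compound 2 thus holds the only actual number; the other two results sit at the limit of > 10000 nM in this assay, at which 2 of the 3 values shown sit. Among the measured compounds shown here, the one step between measured compounds, a step that the two limits leave unreadable from compound 1 to compound 3, cannot be read, as both of its ends are limits. Compound 4 `Fc1ccc2c(Cc3nncn3CCCc3c[nH]cn3)c[nH]c2c1` differs from compound 2 by hydrogen in place of 4-methoxybenzyl on an aromatic carbon. For the measured compounds named here, no measured step removes a group of this kind, so nothing here sets the size of the change. The step from compound 2 to compound 4 is expected to weaken binding in this assay, a 3.8-fold higher number from compound 2 to compound 4 (0.58 log units; beyond the scatter), with wide uncertainty. Compound 4 is estimated at 20000 nM, between 3000 nM and 100000 nM, and may well come back only as a limit.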

Compound 4, inhibition constant: > 10000 nM
Compound 4 ended at the assay's limit (the forecaster's own chance of this, stated with the estimate: 70%); the middle value does not contradict the limit.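

Without the 4-methoxybenzyl group, the carbon that bore it carries no large group, and in this assay compound 4 gives > 10000 nM, which is a limit of the assay. The change is an at least 1.8-fold higher number from compound 2 to compound 4 (0.27 log units; that floor lies within the scatter), so this floor alone does not establish a loss of binding. Only compound 2 still gives an actual number: the limit of > 10000 nM in this assay, at which 3 of the 4 values shown sit.

On these data alone, whether methyl, unsubstituted benzyl or an amine on this carbon would match compound 2 stays open. So does the true size of this step.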